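The compounds below may be only part of what the source reports. "The series", "measured", "known", "first", "only" and "open" are said of these compounds alone.

Compound 1, `CSc1nc(NCc2ccccc2)c2c(n1)C(=O)C(c1ccccc1)=[N+]2[O-]`, and compound 2, `Nc1nc(NCc2ccccc2)nc2c1[N+]([O-])=C(c1ccccc1)C2=O`, share a core and differ in the groups attached to it. In a functional assay on SW1573 cells (Homo sapiens) for antiproliferative activity, read by sulforhodamine B assay, with a stated time of 48 h (a lower number here means a stronger inhibitor of growth, a higher number a weaker inhibitor of growth), compound 1 gives 26000 nM, and compound 2 gives 30000 nM; the two numbers lie within the scatter of each other, so neither can be called the stronger inhibitor. Compound 3, `Nc1nc(NCCN2CCCC2)nc2c1[N+]([O-])=C(c1ccccc1)C2=O`, is the next compound. It carries the change ((pyrrolidin-1-yl)methyl in place of phenyl on a saturated chain carbon bound to a nitrogen on an aromatic ring). Within the data shown here, no measured pair shows a step of this kind, so only a modest shift is expected, and compound 3 is estimated at 20000 nM, most likely between 6000 nM and 60000 nM, a step from compound 2 of a 1.5-fold lower number from compound 2 to compound 3 (0.18 log units; within the scatter).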

Compound 3, concentration for 50% growth inhibition: 6200 nM
Beside the measured number, compound 3's estimate is 3.2-fold (0.51 log units) above it, and the stated range covers the measured number.
By their numbers in this assay, from the lowest: compound 3; then compounds 1 and 2 (each within the scatter of the next).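

In this assay, the position on a saturated chain carbon bound to a nitrogen on an aromatic ring proves sensitive to what it carries: (pyrrolidin-1-yl)methyl in place of phenyl gives a 4.8-fold lower number from compound 2 to compound 3 (0.68 log units; beyond the scatter). Nothing given here accounts for this step. The compounds shown leave open whether the pyrrolidine ring itself matters or only an amine on the chain, which a piperidine, a dimethylamino group or a longer chain at this place could separate. They also leave open whether the same change would carry over to the core of compound 1.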